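Nitro in Place of Amino on a Fluorinated Stilbene

The compounds below may be only part of what the source reports. "The series", "measured", "known", "first", "only" and "open" are said of these compounds alone.

Compound 1 `COc1ccc(/C(F)=C\c2cc(OC)c(OC)c(OC)c2)cc1N` is the weaker of the two compounds measured in a functional assay on cells (Endothelial cell, Bos taurus) for antiproliferative activity (a lower number here means a stronger inhibitor, a higher number a weaker inhibitor), where compound 1 gives 2100 nM. Its nearest comparator, compound 2 `COc1cc(/C=C\c2cc(O)c3ccoc3c2)cc(OC)c1OC`, gives 49 nM in this assay, a gap well beyond the scatter. Compound 3 `COc1ccc(/C(F)=C\c2cc(OC)c(OC)c(OC)c2)cc1[N+](=O)[O-]` differs from compound 1 in one place: nitro in place of amino on an aromatic carbon. Among the compounds with values here, no measured pair shows this change, so its size is open. Compound 3 is expected to come out somewhat weaker, a step of a 2.1-fold higher number from compound 1 to compound 3 (0.33 log units; beyond the scatter) just beyond the scatter. Compound 3 is estimated at 4500 nM, within a range from 1500 nM to 14000 nM.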

Compound 3, half-maximal inhibitory concentration: 329000 nM
Estimate against measurement, compound 3: 73-fold (1.86 log units) below, outside the stated range (above it).
By their numbers in this assay, from the lowest: compound 2; then compound 1; then compound 3.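

In this assay, the aromatic carbon ortho to a methoxy group proves highly sensitive to the group it carries: nitro in place of amino gives a 160-fold higher number from compound 1 to compound 3 (2.19 log units; beyond the scatter). On this fluorinated core, the amino compound is therefore clearly the stronger of the pair. Nothing available explains the size of this step. From the compounds shown here alone, whether a hydroxyl, an acetamide or a dimethylamino group at this position would stay close to compound 1 or fall towards compound 3 remains open. So does whether the same step would appear on a core without the fluorine.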